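The compounds below may be only part of what the source reports. "The series", "measured", "known", "first", "only" and "open" are said of these compounds alone.

Three compounds share one core and differ only in the group on the amide-type nitrogen. Compound 1 `O=C(NC1CCN(Cc2ccccc2)CC1)c1c(O)c2cccnc2n(-c2ccccc2)c1=O` gives 1.2% in a functional assay on the whole organism for inhibition, with Rattus norvegicus as the target, read by cytopathic effect and paw edema, at a dose of 100 mg/kg by the oral route; a lower number here means less inhibition, a higher number more inhibition at the dose given (going by the name of the read-out); compound 2 `COc1ccc(NC(=O)c2c(O)c3cccnc3n(-c3ccccc3)c2=O)cc1` gives -1.9% in this assay; compound 3 `O=C(Nc1ccc(Cl)cc1)c1c(O)c2cccnc2n(-c2ccccc2)c1=O` gives 2.5% in this assay. Compound 2 stands at the lowest of the three numbers, though its gaps to compound 1 and to compound 3 both lie within the scatter. For the measured compounds named here, the only single-place step among the measured compounds is a number 4.4 percentage points higher from compound 2 to compound 3 (within the scatter), which is itself within the scatter. Compound 4 `O=C(Nc1cccc([N+](=O)[O-])c1)c1c(O)c2cccnc2n(-c2ccccc2)c1=O` differs from compound 2 by 3-nitrophenyl in place of 4-methoxyphenyl on an amide-type nitrogen. Going by the values given here, the step from compound 2 to compound 3 is the one measured step that bears on this change, and it was small; none of the measured compounds moves the read-out beyond the scatter, so no step beyond the scatter is expected here either. The expected step is a number 3.4 percentage points higher from compound 2 to compound 4 (within the scatter). Compound 4 is therefore estimated at 1.5%, with a range from -8% to 11%.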

Compound 4, a percentage reported as inhibition, in the whole organism at one dose (the size of the read-out at that dose, not a potency): 7.4%
Beside the measured number, compound 4's estimate is 5.9 percentage points below it, and the stated range covers the measured number.
By their numbers in this assay, from the lowest: compounds 2, 1, 3 and 4 (each within the scatter of the next).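

With 3-nitrophenyl on the amide-type nitrogen, the result in this assay is a number 9.3 percentage points higher from compound 2 to compound 4 (within the scatter) and a number 4.9 percentage points higher from compound 3 to compound 4 (within the scatter), so both steps stay within the scatter. A third aromatic group, now carrying a nitro group rather than a methoxy group or a chlorine, therefore still leaves all the compounds with one-place differences at this nitrogen undistinguished by this read-out at the single dose given. Nothing available explains these steps or the read-out of compound 4.

The compounds shown leave open whether any group at this nitrogen can move the read-out beyond the scatter, for instance a phenyl ring bearing a carboxylic acid or a primary amine, or a longer alkyl chain in place of the ring. They also leave open whether changes elsewhere on the shared core would do so.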